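The compounds below may be only part of what the source reports. "The series", "measured", "known", "first", "only" and "open" are said of these compounds alone.

Measured so far:
Compound 1 `CN(C(=O)NC(=O)c1ccc(F)c(F)c1)c1nc(C(F)(F)F)c(C(=O)N/N=C/c2ccc(C(F)(F)F)cc2)s1`: 6.26 ug/mL
Compound 2 `CN(C(=O)NC(=O)c1ccc(F)c(F)c1)c1nc(C(F)(F)F)c(C(=O)N/N=C/c2cccc(C(F)(F)F)c2)s1`: 5.6 ug/mL

Among the measured compounds shown here, in a functional assay on HepG2 cells (Homo sapiens) for inhibition, read by MTT assay, with a stated time of 72 h (a lower number here means a stronger inhibitor, a higher number a weaker inhibitor), compound 1 carries the higher of the two numbers, but the only measured step, a 1.1-fold lower number from compound 1 to compound 2 (0.05 log units; within the scatter), is within the scatter, so the two are not separated. Compound 3 `CN(C(=O)NC(=O)c1c(F)cccc1F)c1nc(C(F)(F)F)c(C(=O)N/N=C/c2ccc(C(F)(F)F)cc2)s1` differs from compound 1 by 2,6-difluorophenyl in place of 3,4-difluorophenyl on a carbonyl carbon. For the measured compounds named here, no measured step touches this part of the molecule; the one step available concerns the group on the carbon doubly bonded to nitrogen and was within the scatter. Nothing here supports a step beyond the scatter, so the expected step is a 1.0-fold higher number from compound 1 to compound 3 (0.00 log units; within the scatter). Compound 3 is therefore estimated at 6.3 ug/mL, with a range of 2.5 ug/mL to 16 ug/mL.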

Compound 3, half-maximal inhibitory concentration: 49.6 ug/mL
Estimate against measurement, compound 3: 7.9-fold (0.90 log units) below; measured number above the stated range.
By their numbers in this assay, from the lowest: compounds 2 and 1 (each within the scatter of the next); then compound 3.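

In this assay the phenyl on the carbonyl carbon responds to the arrangement of its fluorines alone: 2,6-difluorophenyl in place of 3,4-difluorophenyl gives a 7.9-fold higher number from compound 1 to compound 3 (0.90 log units; beyond the scatter) with the heavy-atom count unchanged. Among the compounds shown here, the earlier pair covered only the group on the carbon doubly bonded to nitrogen and stayed within the scatter, so this is the first change to move the number beyond it. Nothing measured here accounts for the step.

Still open, going by these compounds, is whether a plain phenyl, 4-fluorophenyl or a pyridine ring on this carbonyl carbon would sit nearer compound 1 or compound 3. On these data alone, it is also open whether 2,6-difluorophenyl carries the same penalty alongside 3-(trifluoromethyl)phenyl.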